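Vero toxicity notes: compound 2 to compound 4

The source may hold more compounds than are shown below. What is called first, only, known or untested is meant among the compounds shown, and "the series" means these compounds.

Measured so far in a toxicity assay on Vero cells (Chlorocebus sabaeus) for inhibition; on this read-out higher numbers stand for an effect only at larger amounts of compound and lower numbers for an effect already at smaller amounts:
- compound 1, `COc1cccc(NC(=O)c2nnn(CC3CCNCC3)c2N)c1`; compound 1 reaches only the limit of the assay, > 50100 nM
- compound 2, `COc1cccc(NC(=O)c2nnn(Cc3ccc(-n4cccn4)cc3)c2N)c1`; compound 2 likewise reaches only the limit, > 50100 nM
- compound 3, `COc1cccc(NC(=O)c2nnn(C(CO)c3ccc(C(C)C)cc3)c2N)c1`; compound 3 gives a number, 12600 nM

Compound 2 stands at the limit of this assay: its result is not a number but the ceiling of what was tested, and compound 1 shares that standing. Among the compounds with values here, compound 3 is the only compound of the three with a number, and no step between measured compounds is counted, so there is no measured step that could guide the change now in question.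

Compound 4, `COc1cccc(NC(=O)c2nnn(Cc3ccc(OC(F)(F)F)cc3)c2N)c1`, differs from compound 2 in one place: trifluoromethoxy in place of 1H-pyrazol-1-yl on an aromatic carbon. Since the limit of > 50100 nM in this assay, at which 2 of the 3 values shown sit, marks where two of the three values sit, nothing shown points to a move beyond the scatter in this assay; the expected step in this assay is none beyond the scatter, and the most probable outcome is that compound 4 is again reported only as a limit. Compound 4 is therefore estimated at 50000 nM, with a range from 20000 nM to 120000 nM. The corresponding expected step is a number no higher from compound 2 to compound 4 (the limit leaves the size open).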

Compound 4, half-maximal effective concentration: > 50100 nM
Compound 4 was reported as a limit (the forecaster's own chance of this, stated with the estimate: 65%); at least 1.0-fold (0.00 log units) between middle value and limit.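

In this assay compound 2 and compound 4 are both reported only as limits, so no step between them can be read, and the comparison rests on the ceiling they share: the limit of > 50100 nM in this assay, at which 3 of the 4 values shown sit.

The compounds shown leave open whether trifluoromethoxy in place of 1H-pyrazol-1-yl shifts this read-out at all, and how far either compound lies from that limit.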